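Ethyl to isopropyl in a clearance series

The source may hold more compounds than are shown below. What is called first, only, known or untested is meant among the compounds shown, and "the series" means these compounds.

Within the data shown here, in an ADME assay (liver) for metabolic stability, with Liver microsome (Homo sapiens) as the target, using microsomes and NADPH, with a stated time of 30 min, tested at 1 uM (on this read-out higher numbers stand for fast clearance and lower numbers for slow clearance), compound 2 `CCn1cc(-c2cc(C(O)(C(F)(F)F)C(F)(F)F)cnc2N2CCN(S(=O)(=O)c3ccc(N)nc3)CC2)cn1` gives 20 mL.min-1.g-1 as the only actual number so far. Compound 1 `CC(C)(O)C#Cc1cc(C(O)(C(F)(F)F)C(F)(F)F)cnc1N1CCN(S(=O)(=O)c2ccc(N)nc2)CC1` stands at < 14 mL.min-1.g-1 which is a limit of the assay and not a number. Among the measured compounds shown here, the only measured step is an at least 1.4-fold higher number from compound 1 to compound 2 (0.15 log units; that floor lies within the scatter) and it exchanges a whole substituent, so it says little about one added methyl. Compound 3 `CC(C)n1cc(-c2cc(C(O)(C(F)(F)F)C(F)(F)F)cnc2N2CCN(S(=O)(=O)c3ccc(N)nc3)CC2)cn1` differs from compound 2 by methyl in place of hydrogen on a saturated chain carbon bound to an aromatic nitrogen and a saturated chain carbon which reads as ethyl to isopropyl. For the measured compounds named here, no step of this kind has been measured, so the estimated step of a 1.3-fold higher number from compound 2 to compound 3 (0.10 log units; within the scatter) is expected to stay within the scatter. Compound 3 is expected at 25 mL.min-1.g-1 with 13 mL.min-1.g-1 to 48 mL.min-1.g-1 as its estimated range.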

Compound 3, intrinsic clearance in microsomes: 38 mL.min-1.g-1
Compound 3: the middle estimate sits 1.5-fold (0.18 log units) below what was measured, within the range that was stated.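

In this assay, methyl in place of hydrogen on the saturated chain carbon gives a 1.9-fold higher number from compound 2 to compound 3 (0.28 log units; within the scatter), so this change alone does not separate the two compounds. Exchanging 3-hydroxy-3-methylbut-1-yn-1-yl for 1-isopropyl-1H-pyrazol-4-yl gives an at least 2.7-fold higher number from compound 1 to compound 3 (0.43 log units; beyond the scatter), the only step shown that passes the scatter. The value of compound 1 is a limit of the assay and not a number, so that step is a floor: the limit of < 14 mL.min-1.g-1 in this assay, at which 1 of the 3 values shown sits.

On these data alone, it remains open how a cyclopropyl group or a longer chain in place of isopropyl would read in this assay.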